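Cyclohexyl Ether in Place of Methoxyphenyl Ether

This account rests on a few compounds, and the source may have more. Where it says the series, first, only, none or still open, it means among the compounds named here.

Of the compounds shown here, three built on one shared core have been tested in an ADME assay on MRC5 cells (Homo sapiens) for cytotoxicity, read by fluorescence and resazurin assay, with a stated time of 3 days; on this read-out lower numbers stand for stronger inhibition and higher numbers for weaker inhibition. Compound 1 `Cc1cn(C2CCN(Cc3cc(Oc4cccc(Cl)c4)ccn3)CC2)c(=O)[nH]c1=O` returns only a limit of the assay rather than a number, > 64000 nM. Compound 3 `Cc1cn(C2CCN(Cc3cncc(Oc4cc(Cl)cc(Cl)c4)c3)CC2)c(=O)[nH]c1=O` likewise returns only a limit, > 64000 nM. For the measured compounds named here, compound 2 `COc1ccc(Oc2cccc(CN3CCC(n4cc(C)c(=O)[nH]c4=O)CC3)c2)cc1` is the single compound with a number: in this assay compound 2 gives 28000 nM, while the other two results sit at the limit of > 64000 nM in this assay, at which 2 of the 3 values shown sit.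

Compound 4 `Cc1cn(C2CCN(Cc3cccc(OC4CCCCC4)c3)CC2)c(=O)[nH]c1=O` has not yet been measured. It differs from compound 2 in one place: cyclohexyl in place of 4-methoxyphenyl on an oxygen on an aromatic ring. Going by the values given here, no step between two measured compounds is available here, so the change has no direct precedent in this set. Given that compound 2 itself gives 28000 nM, the step from compound 2 to compound 4 in this assay is expected to be small, within the usual scatter or drifting toward weaker inhibition. Compound 4 is estimated at 40000 nM, expected to fall between 15000 nM and 64000 nM. The step of a 1.4-fold higher number from compound 2 to compound 4 (0.15 log units; within the scatter) is expected to stay within the usual scatter.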

Compound 4, half-maximal inhibitory concentration: 23600 nM
For compound 4 the middle estimate is 1.7-fold (0.23 log units) above the measured one; measured number inside the range.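

In this assay, cyclohexyl in place of 4-methoxyphenyl gives a 1.2-fold lower number from compound 2 to compound 4 (0.07 log units; within the scatter), so in this pair the group on the oxygen on the aromatic ring can change without a step that can be told from the scatter. For the compounds shown here, the pair shows that neither the aromatic ring nor the oxygen of the leaving 4-methoxyphenyl is needed to keep the number where it stands, a comparison the earlier compounds could not offer. The two other compounds shown give only a limit of the assay, not a number: the limit of > 64000 nM in this assay, at which 2 of the 4 values shown sit.

This single step cannot show whether the same swap would behave alike on another ring of the shared core. It also leaves open how a piperidine amine or a carboxylic acid on that oxygen, in place of cyclohexyl, would read in this assay.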